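From 3-nitrobenzyl to 4-aminobenzyl

This account rests on a few compounds, and the source may have more. Where it says the series, first, only, none or still open, it means among the compounds named here.

In a toxicity assay on NIH3T3 cells (Mus musculus) for cytotoxicity, read by resazurin assay (on this read-out higher numbers stand for an effect only at larger amounts of compound and lower numbers for an effect already at smaller amounts), compound 1 `COC(=O)c1ccc(NCc2cncn2Cc2ccc(Cl)cc2)cc1-c1ccccc1` gives 25000 nM. Compound 2 `COC(=O)c1ccc(NCc2cncn2Cc2cccc([N+](=O)[O-])c2)cc1-c1ccccc1` gives > 10000 nM, which is a limit and not a number. Compound 3 `COC(=O)c1ccc(NCc2cncn2Cc2ccc(N)cc2)cc1-c1ccccc1` carries 4-aminophenyl in place of 3-nitrophenyl on a saturated chain carbon bound to an aromatic nitrogen. Among the measured compounds shown here, the only measured step at this place is a step that the limit leaves unreadable from compound 1 to compound 2, and the evidence is the limit of > 10000 nM in this assay, at which 1 of the 2 values shown sits. For the measured compounds named here, with compound 1 at 25000 nM as the only readable number, no step beyond the scatter is expected in this assay, and no direction can be given: a step that the limit leaves unreadable from compound 2 to compound 3. For compound 3 the estimated value is 18000 nM, with an expected range of 7000 nM to 50000 nM.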

Compound 3, half-maximal effective concentration: > 10000 nM
Compound 3 gave a limit, no number; the forecaster's own chance of this, stated with the estimate: 45%; the middle value is on the limit's open side.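

In this assay compound 3 gives > 10000 nM, a limit and not a number, so no step among compound 1, compound 2 and compound 3 can be read: the limit of > 10000 nM in this assay, at which 2 of the 3 values shown sit.

The compounds shown leave open how far compound 2 and compound 3 lie from compound 1, or from each other, on this read-out.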